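Working notes: a chain stereocentre, compound 2 to compound 3

The compounds below may be only part of what the source reports. "The series", "measured", "known", "first", "only" and "open" are said of these compounds alone.

Measured so far in a functional assay on Remb1 cells for cytotoxicity, read by MTT assay, with a stated time of 24 h; on this read-out lower numbers stand for stronger inhibition and higher numbers for weaker inhibition:
- compound 1 `CC(C)=CCC[C@@H](C)[C@@H]1C=C[C@]2(C(=O)O)[C@@H](CC(C)=C[C@H]2/C=C(\C)[C@H]2CC[C@H](C(=O)O)CC2)C1`: > 20000 nM (a limit)
- compound 2 `CC(C)=CCC[C@H](C)[C@@H]1C=C[C@]2(C(=O)O)[C@@H](CC(C)=C[C@H]2/C=C(\C)c2ccc(C(=O)O)cc2)C1`: > 20000 nM (a limit)

Compound 2 gives > 20000 nM in this assay, and this is a limit of the assay rather than a number. Compound 1 gives > 20000 nM, also a limit. Within the data shown here, the series so far therefore comes down to the limit of > 20000 nM in this assay, at which 2 of the 2 values shown sit.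

Compound 3 `CC(C)=CCC[C@@H](C)[C@@H]1C=C[C@]2(C(=O)O)[C@@H](CC(C)=C[C@H]2/C=C(\C)c2ccc(C(=O)O)cc2)C1` is not yet measured. From compound 2 to compound 3 the change is this: the two compounds have the same atoms and bonds and differ only in configuration as drawn: 1 of 6 stereo elements differ; a stereocentre at a saturated chain carbon is drawn S in compound 2 and R in compound 3.

Among the measured compounds shown here, no measured step shows what a change of this kind does, so no step beyond the scatter is expected in this assay, and no direction is favoured. Another limit is the most likely report. The estimated step is a step that the limit leaves unreadable from compound 2 to compound 3. For compound 3 the expected value is 25000 nM, with an estimated range of 12000 nM to 50000 nM.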

Compound 3, half-maximal inhibitory concentration: 8600 nM
The estimate for compound 3 lay 2.9-fold (0.46 log units) above the measured number; the measured number lies below the stated range.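

In this assay, among these compounds, inverting the saturated chain stereocentre from S to R gives an at least 2.3-fold lower number from compound 2 to compound 3 (0.36 log units; beyond the scatter), the first step that ends on a measured number, and it comes from configuration alone: the fact that compounds 2 and 3 differ only in the configuration as drawn. With the chain stereocentre drawn alike, 4-carboxyphenyl in place of 4-carboxycyclohexyl gives an at least 2.3-fold lower number from compound 1 to compound 3 (0.36 log units; beyond the scatter), so this position also bears on the read-out. The full size of both steps cannot be read because the series still rests mostly on a limit: the limit of > 20000 nM in this assay, at which 2 of the 3 values shown sit.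

The compounds shown leave open whether the R configuration at the chain carbon keeps its advantage when the 4-carboxyphenyl group gives way to another group. They also leave open what an amide or an amine would do in place of the carboxylic acid on that ring.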